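The source may report more compounds than this note shows. Statements on the series, on what has been measured and on what is new or still open speak of the compounds shown alone.

Within the data shown here, compound 2 `O=S(=O)(NCCCNCc1ccc(-c2ccccc2)cc1)c1cc(C(F)(F)F)cc(C(F)(F)F)c1` gives 2600 nM in a functional assay on A2780 cells (Homo sapiens) for inhibition, read by MTT assay, with a stated time of 72 h (a lower number here means a stronger inhibitor of growth, a higher number a weaker inhibitor of growth), the lowest of the two numbers measured so far, though compound 1 `O=S(=O)(NCCCNCc1ccc(C(F)(F)F)cc1)c1cc(C(F)(F)F)cc(C(F)(F)F)c1` at 2800 nM sits within the scatter of it, as the step of a 1.1-fold lower number from compound 1 to compound 2 (0.03 log units; within the scatter) shows. Compound 3 `COc1ccc(CNCCCNS(=O)(=O)c2cc(C(F)(F)F)cc(C(F)(F)F)c2)cc1` carries the change (methoxy in place of phenyl on an aromatic carbon). Among the measured compounds shown here, only that one measured step bears on a swap at this position, and it left the number essentially unchanged, so no step beyond the scatter is expected in this assay, with a 1.2-fold higher number from compound 2 to compound 3 (0.06 log units; within the scatter) as the estimated shift. Compound 3 is therefore expected to give about 3000 nM, within a range of 1200 nM to 7500 nM.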

Compound 3, concentration for 50% growth inhibition: 1700 nM
Estimate against measurement, compound 3: 1.8-fold (0.25 log units) above, and the stated range covers the measured number.
By their numbers in this assay, from the lowest: compounds 3, 2 and 1 (each within the scatter of the next).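

In this assay, methoxy on this aromatic carbon gives no step beyond the scatter against either earlier group, with a 1.5-fold lower number from compound 2 to compound 3 (0.18 log units; within the scatter) and a 1.6-fold lower number from compound 1 to compound 3 (0.22 log units; within the scatter). All three compounds therefore lie within the scatter of one another, even though the change removes a ring and brings in a hydrogen-bond acceptor. Nothing available explains this flat result. Going by these compounds, it remains open whether an amine, a carboxylic acid or a nitrile at this position would move the number beyond the scatter. The same holds for a longer chain in the shared core.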